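Aryl versus alkyl sulfonyl groups on an indole-type chalcone core

The compounds below may be only part of what the source reports. "The series", "measured", "known", "first", "only" and "open" are said of these compounds alone.

Measured compounds and values:
- compound 1, `O=C(/C=C/c1cn(S(=O)(=O)c2ccc(Cl)cc2)c2ccccc12)c1ccncc1`, in a functional assay on HepG2 cells (Homo sapiens) for antiproliferative activity, read by MTT assay, with a stated time of 48 h (on this read-out lower numbers stand for stronger inhibition and higher numbers for weaker inhibition), compound 1 gives 35100 nM
- compound 2, `CCCS(=O)(=O)n1cc(/C=C/C(=O)c2ccncc2)c2ccccc21`, in this assay compound 2 gives 46200 nM
- compound 3, `O=C(/C=C/c1c[nH]c2ccccc12)c1ccncc1`, in this assay compound 3 gives 49300 nM

Compound 2 sits in the middle of three values that all lie within the usual scatter of one another, so none of the three can be called stronger or weaker than another. The steps confirm this: a 1.3-fold higher number from compound 1 to compound 2 (0.12 log units; within the scatter), and a 1.1-fold higher number from compound 2 to compound 3 (0.03 log units; within the scatter). Swapping an aryl group for a propyl chain on the sulfonyl sulfur, or removing the sulfonyl group altogether, left the number essentially unchanged.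

Compound 4, `O=C(/C=C/c1cn(S(=O)(=O)c2cccc([N+](=O)[O-])c2)c2ccccc12)c1ccncc1`, is the next compound to be tested. Compared with compound 2 the change is 3-nitrophenyl in place of propyl on a sulfonyl sulfur. Within the data shown here, the step most closely related to this change is the one from compound 1 to compound 2, which replaced an aryl group on the same sulfonyl sulfur with propyl and stayed within the scatter. The new compound brings an aryl group back to that position, carrying a nitro group rather than a chlorine. On that basis no step beyond the scatter is expected in this assay, with at most a slight drift toward a lower number like that of compound 1; the step from compound 2 to compound 4 is estimated as a 1.3-fold lower number from compound 2 to compound 4 (0.11 log units; within the scatter). Compound 4 is therefore expected to give about 36000 nM, within a range from 15000 nM to 90000 nM.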

Compound 4, half-maximal inhibitory concentration: 42600 nM
The estimate for compound 4 lay 1.2-fold (0.07 log units) below the measured number, and the stated range covers the measured number.
By their numbers in this assay, from the lowest: compounds 1, 4, 2 and 3 (each within the scatter of the next).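

In this assay, putting 3-nitrophenyl on the sulfonyl sulfur in place of propyl adds a six-membered aromatic ring and two hydrogen-bond acceptors, yet the result is only a 1.1-fold lower number from compound 2 to compound 4 (0.04 log units; within the scatter) and compound 4 gives 42600 nM. Among these compounds, exchanging one substituted aryl group for another, 3-nitrophenyl in place of 4-chlorophenyl, gives a 1.2-fold higher number from compound 1 to compound 4 (0.08 log units; within the scatter), so this assay does not tell these two aryl groups apart, and earlier compounds had offered only one aryl group at this position. Nothing available explains why such different groups on this sulfur leave the number within the scatter.

Still open, going by these compounds, is whether a group of another kind on the sulfonyl sulfur, such as an amine-bearing chain, a carboxylic acid or a longer alkyl chain, would produce a step beyond the scatter. These compounds also leave open whether any change to the shared core itself, rather than to the group on the sulfonyl sulfur, would move the number in this assay.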